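This account rests on a few compounds, and the source may have more. Where it says the series, first, only, none or still open, it means among the compounds named here.

In a functional assay on MCF7 cells (Homo sapiens) for antiproliferative activity, read by MTT assay, with a stated time of 72 h (a higher number here means a weaker inhibitor, a lower number a stronger inhibitor), compound 2 (`O=C1O[C@H]([C@@H](O)Cn2cc(CNS(=O)(=O)c3ccc(Cl)cc3)nn2)C(OCc2ccccc2)=C1OCc1ccccc1`) gives 4170 nM and compound 3 (`C[Si](C)(C)c1cn(C[C@H](O)[C@H]2OC(=O)C(OCc3ccccc3)=C2OCc2ccccc2)nn1`) gives 12100 nM, the higher of these two numbers. Compound 1 (`COc1ccccc1-c1cn(C[C@H](O)[C@H]2OC(=O)C(OCc3ccccc3)=C2OCc2ccccc2)nn1`) reaches only a limit of the assay, > 100000 nM.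

The change to compound 4 (`O=C1O[C@H]([C@@H](O)Cn2ccnn2)C(OCc2ccccc2)=C1OCc1ccccc1`) is a hydrogen atom in place of a group of 4 heavy atoms (3 carbon, 1 silicon; no ring), on an aromatic carbon. Among the measured compounds shown here, no measured step places hydrogen on this carbon. The closest evidence is a 2.9-fold higher number from compound 2 to compound 3 (0.46 log units; beyond the scatter), which is modest, and an at least 8.2-fold lower number from compound 1 to compound 3 (0.91 log units; beyond the scatter), which is at least modest. Both show that this substituent matters but do not fix the direction for hydrogen, so only a tentative, modest step toward a higher number is expected in this assay. The expected step is a 2.1-fold higher number from compound 3 to compound 4 (0.32 log units; beyond the scatter). For compound 4, the estimated value is 25000 nM, with an expected range of 6000 nM to 100000 nM.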

Compound 4, half-maximal inhibitory concentration: > 100000 nM
Compound 4: no number, only a limit (the forecaster's own chance of this, stated with the estimate: 20%); middle value at least 4.0-fold (0.60 log units) away from the limit.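

Compound 4, with hydrogen on this aromatic carbon, stands at a limit of this assay, shared with compound 1: the limit of > 100000 nM in this assay, at which 2 of the 4 values shown sit.

Both readable steps run the same way, an at least 8.2-fold higher number from compound 3 to compound 4 (0.91 log units; beyond the scatter) and an at least 23-fold higher number from compound 2 to compound 4 (1.37 log units; beyond the scatter), so among these compounds a readable number requires a group on this carbon, though compound 1 shows that not every group gives one. The step between compound 1 and compound 4 cannot be read.

Still open, from the compounds shown here alone, is whether methyl, an amine or a carboxylic acid on this carbon gives a readable number. Also open, going by these compounds, is whether phenyl without the methoxy group behaves like 2-methoxyphenyl.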